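The source may hold more compounds than are shown below. What is called first, only, known or untested is meant among the compounds shown, and "the series" means these compounds.

Measured compounds:
Compound 1, `C/C=C/c1cc(=O)[nH]c(=O)n1C1O[C@H](CO)[C@@H](O)[C@H]1O`, gives > 35000 nM in a functional assay on L1210 cells (Mus musculus) for inhibition (a higher number here means a weaker inhibitor, a lower number a stronger inhibitor), which is a limit of the assay.
Compound 2, `CCOC(=O)/C=C/c1cc(=O)[nH]c(=O)n1C1O[C@H](CO)[C@@H](O)[C@H]1O`, gives > 35000 nM in this assay, again a limit.
Compound 3, `C/C=C/c1cc(O)nc(O)n1`, gives > 90000 nM in this assay, also a limit.

Compound 2 is compound 1 with ethoxycarbonyl in place of methyl on a double-bonded chain carbon bound to a double-bonded chain carbon. The step that the two limits leave unreadable from compound 1 to compound 2 cannot be sized, as the limit of > 35000 nM in this assay, at which 2 of the 3 values shown sit, shows. Compound 1 and compound 3 differ in more than one place; how their two cores differ is not broken down here. Compound 4, `CCOC(=O)/C=C/c1cc(O)nc(O)n1`, is compound 3 carrying the same change: ethoxycarbonyl in place of methyl on a double-bonded chain carbon bound to a double-bonded chain carbon. For compound 4 the expected step is a step that the limit leaves unreadable from compound 3 to compound 4. This rests on the measured step that the two limits leave unreadable from compound 1 to compound 2 being hidden between two limits and on compound 3 sitting at the limit of > 90000 nM in this assay, at which 1 of the 3 values shown sits, so no gain is foreseen. Compound 4 is estimated at 100000 nM, within 30000 nM to 300000 nM.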

Compound 4, half-maximal inhibitory concentration: 38000 nM
For compound 4 the middle estimate is 2.6-fold (0.42 log units) above the measured one; the measured number falls inside the stated range.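

On the core of compound 3, ethoxycarbonyl in place of methyl gives an at least 2.3-fold lower number from compound 3 to compound 4 (0.37 log units; beyond the scatter) in this assay, so the change has a visible effect on this core. The same change on the core of compound 1 cannot be read, because both values there are limits of the assay: the limit of > 35000 nM in this assay, at which 2 of the 4 values shown sit. The gain is therefore seen on one core only, and this does not show whether it carries over from one core to the other, nor how large it would be there.

Going by these compounds, it remains open whether a carboxylic acid in the same place would lower the number as ethoxycarbonyl does. On these data alone, a longer chain in place of methyl is equally open.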